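A few compounds are considered here, and "the series" means these few. Any claim that something is new, unique, unknown or untested is made for them only; others in the source may bear on it.

Compound 1, `Cc1ccc(/C=C2\CCC/C(=C\c3cccc([N+](=O)[O-])c3)C2=O)cc1`, gives 9530 nM in a functional assay on MOLT-4 cells (Homo sapiens) for cytotoxicity, with a stated time of 72 h; on this read-out higher numbers stand for weaker inhibition and lower numbers for stronger inhibition.
Compound 2, `Cc1ccc(/C=C2\CCC/C(=C\c3ccc([N+](=O)[O-])cc3)C2=O)cc1`, gives 8440 nM in this assay.
Compound 3, `O=C1/C(=C/c2ccc(F)cc2)CCC/C1=C\c1cccc([N+](=O)[O-])c1`, gives 5120 nM in this assay.

All three numbers lie within the usual scatter of one another, so no order among the three can be read from them. Compound 1 and compound 3 differ in one place, (fluoro in place of methyl on an aromatic carbon), and that change made a 1.9-fold lower number from compound 1 to compound 3 (0.27 log units; within the scatter). Compound 2 is built from the same atoms as compound 1, joined differently; the difference between the two cores is not broken down here.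

Compound 4, `O=C1/C(=C/c2ccc(F)cc2)CCC/C1=C\c1ccc([N+](=O)[O-])cc1`, has not yet been measured. It stands to compound 2 as compound 3 stands to compound 1: the change is fluoro in place of methyl on an aromatic carbon, at the same place on the ring. The step from compound 2 to compound 4 is expected to be roughly a 1.8-fold lower number from compound 2 to compound 4 (0.25 log units; within the scatter), because the same change once gave a 1.9-fold lower number from compound 1 to compound 3 (0.27 log units; within the scatter), though that rests on a single pair. Compound 4 is accordingly estimated at 4800 nM, most likely falling between 2500 nM and 9500 nM.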

Compound 4, half-maximal inhibitory concentration: 17100 nM
Compound 4: the middle estimate sits 3.6-fold (0.55 log units) below what was measured; the whole stated range lies below it.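

In this assay, the same swap of methyl for fluoro gave a 2.0-fold higher number from compound 2 to compound 4 (0.31 log units; beyond the scatter). Set beside the earlier pair, this step does not repeat the first one, so the result of the change did not carry from the core of compound 1 to the core of compound 2: the same change on two cores in this assay, a 1.9-fold lower number (0.27 log units; within the scatter) from compound 1 to compound 3 and a 2.0-fold higher number (0.31 log units; beyond the scatter) from compound 2 to compound 4, 3.8-fold (0.58 log units) apart, beyond the scatter of two such steps

Among these compounds, this shows that one pair is a poor guide to the same change on a neighbouring core, but it does not show why the two cores part ways, and with only two pairs, one of them within the scatter and the other a modest step, it gives no rule for any further core.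

The compounds shown leave open whether the two cores would also part ways for other groups at this place on the ring, such as chloro, methoxy or an amine. They also leave open how a third core would respond to the swap of methyl for fluoro.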